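Replacing thiophen-3-yl on the shared core

This account rests on a few compounds, and the source may have more. Where it says the series, first, only, none or still open, it means among the compounds named here.

compound 1 `Cn1cc(-c2cn3c(Cc4ccc5ncccc5c4)cnc3cc2C#N)cn1` gives "not determined" (no result reported)
compound 2 `Fc1cc(-c2cnn(C3CCNCC3)c2)cn2c(Cc3ccc4ncccc4c3)cnc12` gives 1.46 nM
compound 3 `Fc1cc(-c2ccsc2)cn2c(Cc3ccc4ncccc4c3)cnc12` gives 444 nM

In a functional assay on EBC-1 cells (Homo sapiens) for antiproliferative activity, with a stated time of 72 h (a higher number here means a weaker inhibitor, a lower number a stronger inhibitor), compound 3 reads 444 nM and holds the higher of the two numbers available. Compound 2 lies at 1.46 nM in a gap well beyond the scatter, while compound 1 has no number. Compound 4 `N#Cc1ccc(-c2cc(F)c3ncc(Cc4ccc5ncccc5c4)n3c2)cc1F` remains unmeasured and differs from compound 3 as follows (4-cyano-3-fluorophenyl in place of thiophen-3-yl on an aromatic carbon) with 4-cyano-3-fluorophenyl in place of thiophen-3-yl on an aromatic carbon. Among the compounds with values here, no measured pair isolates this swap, yet compound 2 at 1.46 nM shows that another group on that carbon can go with a far lower number. The expected change is modest and downward, an estimated 3.0-fold lower number from compound 3 to compound 4 (0.47 log units; beyond the scatter) in this assay on this limited evidence. Compound 4 is estimated at 150 nM (expected range 30 nM to 700 nM).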

Compound 4, half-maximal inhibitory concentration: 145 nM
Compound 4: the middle estimate sits 1.0-fold (0.01 log units) above what was measured; the range from low to high includes it.
By their numbers in this assay, from the lowest: compound 2; then compound 4; then compound 3.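

In this assay, within the data shown here, the swap of thiophen-3-yl for 4-cyano-3-fluorophenyl on this aromatic carbon gives a 3.1-fold lower number from compound 3 to compound 4 (0.49 log units; beyond the scatter), the first step at this position read between two measured compounds. A larger six-membered aromatic ring of carbon only therefore goes with a lower number here, yet compound 4 at 145 nM still lies far above compound 2 at 1.46 nM. No measured evidence accounts for this step.

The compounds shown do not separate the share of the nitrile from that of the fluoro in this step. They also leave open whether an aminomethyl group or a carboxylic acid on the six-membered ring would bring the number closer to that of compound 2.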